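The compounds below may be only part of what the source reports. "The series", "measured", "known", "first", "only" and "open" are said of these compounds alone.

The three compounds already measured share a core built around a chlorine-bearing ring double bond, joined through a hydrazone to an aromatic amide. Compound 1 `COc1cccc(/C=N\NC(=O)C2=C(Cl)c3ccccc3CCC2)c1` and compound 2 `O=C(N/N=C/C1=C(Cl)c2ccccc2CCC1)c1cccnc1` differ in their outer aromatic ring, while compound 3 `Cc1cc2c(cc1C)C(Cl)=C(/C=N/NC(=O)c1ccccc1)CCC2` differs from both in its shared core and carries a plain outer ring.

In a functional assay (MiaPaCa cells, Homo sapiens) for inhibition, read by sulforhodamine B assay, with a stated time of 48 h (on this read-out lower numbers stand for stronger inhibition of growth and higher numbers for weaker inhibition of growth), compound 2 gives 11700 nM. For compound 1 this assay reports only a limit, < 10 nM, a boundary of the assay rather than a number, as noted in the limit of < 10 nM in this assay, at which 1 of the 3 values shown sits. Compound 3 likewise sits at a limit, > 100000 nM, the far end of what this assay can report, as noted in the limit of > 100000 nM in this assay, at which 1 of the 3 values shown sits. Compound 3 therefore stands at the weak edge of the measured range, and a second value shown is also a limit, so two of the three values are boundaries rather than numbers.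

Compound 4 `Cc1cc2c(cc1C)C(Cl)=C(/C=N/NC(=O)c1cccc(I)c1)CCC2` differs from compound 3 by iodo in place of hydrogen on an aromatic carbon. Among the compounds with values here, no measured pair shows this change. The step is expected to be an at least 1.6-fold lower number from compound 3 to compound 4 (0.22 log units; that floor lies within the scatter), a modest gain at most, with a real chance that the assay again reports only a limit. Compound 4 is expected to give 60000 nM, within a range from 10000 nM to 200000 nM.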

Compound 4, concentration for 50% growth inhibition: 4300 nM
Estimate against measurement, compound 4: 14-fold (1.14 log units) above; the measured number lies below the stated range.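

Compound 3 gives no number in this assay, only a limit: the limit of > 100000 nM in this assay, at which 1 of the 4 values shown sits. Changing phenyl to 3-iodophenyl, with iodo in place of hydrogen on an aromatic carbon, gives an at least 23-fold lower number from compound 3 to compound 4 (1.36 log units; beyond the scatter), and compound 4 reaches 4300 nM, a true measured number. Within the data shown here, this is the first comparison here between two compounds that differ in one place, and it shows that this position on the plain outer ring is not indifferent, since a single iodine atom is enough to lift the compound off the weak limit of the read-out.

The data do not tell why iodo has this effect, or whether it is special, as no other group at this place appears among the compounds shown; an amine or a carboxylic acid on the same aromatic carbon would begin to answer that. As far as these compounds go, it also remains open whether the same change would act in the same way on the cores of compound 1 and compound 2, which carry other outer rings and lack the two methyl groups of compound 3 and compound 4.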